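This account rests on a few compounds, and the source may have more. Where it says the series, first, only, none or still open, it means among the compounds named here.

Working notes on the series, all read in a functional assay on SW480 cells (Homo sapiens) for antiproliferative activity, read by sulforhodamine B assay, with a stated time of 48 h; a lower number here means a stronger inhibitor, a higher number a weaker inhibitor. Compound 1 `COc1ccc(/C=C/C(=O)c2ccccc2-c2ccc(OC)c(OC)c2)cc1OC` gives 7600 nM, compound 2 `COc1ccc(C(=O)/C=C/c2ccccc2-c2ccc(F)nc2)cc1` gives 10000 nM, and compound 3 `COc1ccc(C(=O)/C=C/c2ccccc2-c2ccc(F)nc2)cc1OC` gives 15000 nM. Compound 3 lies within the scatter of both others, so the three values form one group with no order among them.

The next structure is compound 4 `COc1cc(C(=O)/C=C/c2ccccc2-c2ccc(F)nc2)ccc1O`, and the change is hydrogen in place of methyl on an oxygen on an aromatic ring, or methoxy to hydroxy. Within the data shown here, only one measured step involves a methoxy group: a 1.5-fold higher number from compound 2 to compound 3 (0.18 log units; within the scatter), for methoxy in place of hydrogen on an aromatic carbon. Among the measured compounds shown here, that step bears only indirectly on this change, and no hydroxy compound has been measured yet. On this limited evidence, no step beyond the scatter is expected in this assay, in either direction. The expected step is a 1.4-fold lower number from compound 3 to compound 4 (0.13 log units; within the scatter). For compound 4 the estimated value is 11000 nM, with an expected range from 4500 nM to 25000 nM.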

Compound 4, half-maximal inhibitory concentration: 8500 nM
Compound 4: the middle estimate sits 1.3-fold (0.11 log units) above what was measured; low and high end bracket the measured number.
By their numbers in this assay, from the lowest: compounds 1, 4, 2 and 3 (each within the scatter of the next).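

Methoxy to hydroxy is read here for the first time in the series: hydrogen in place of methyl on an oxygen on an aromatic ring gives a 1.8-fold lower number from compound 3 to compound 4 (0.25 log units; within the scatter) in this assay at this position. The methyl at this position can therefore be exchanged for hydrogen without a step beyond the scatter, and compound 4 stays in one group with compounds 1, 2 and 3. Nothing available explains why the value stays within that group.

From the compounds shown here alone, what a larger group on this oxygen would do, such as a longer chain, or an amine or a carboxylic acid in place of the hydroxy, remains open. Also open, going by these compounds, is whether the same methoxy to hydroxy change would read alike on the other methoxy of compound 3.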